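Replacing the 3-cyanophenyl group of compound 3

This account rests on a few compounds, and the source may have more. Where it says the series, first, only, none or still open, it means among the compounds named here.

Measured in an ADME assay on HEL cells (Homo sapiens) for cytotoxicity, with a stated time of 3 days; a higher number here means that more compound is tolerated, a lower number that less compound is tolerated:
- compound 1 `COc1ccc(-c2cc(C)c3ncc(CSCCc4ccccc4)n3c2)cc1`: 25.8 ug/mL
- compound 2 `Cc1cc(I)cn2c(CSCCc3ccccc3)cnc12`: > 50 ug/mL (a limit)
- compound 3 `Cc1cc(-c2cccc(C#N)c2)cn2c(CSCCc3ccccc3)cnc12`: > 50 ug/mL (a limit)

Compound 3 has no exact number in this assay. Its entry for compound 3 is > 50 ug/mL, which is a limit of the assay. Among the compounds with values here, the series so far shows (the limit of > 50 ug/mL in this assay, at which 2 of the 3 values shown sit).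

Compound 4 `Cc1cc(-c2ccccc2O)cn2c(CSCCc3ccccc3)cnc12` carries 2-hydroxyphenyl in place of 3-cyanophenyl on an aromatic carbon.

Three measured steps change this same carbon. They are an at least 1.9-fold higher number from compound 1 to compound 3 (0.28 log units; that floor lies within the scatter), an at least 1.9-fold higher number from compound 1 to compound 2 (0.28 log units; that floor lies within the scatter) and a step that the two limits leave unreadable from compound 2 to compound 3. Only compound 1, with 4-methoxyphenyl, gives a number, 25.8 ug/mL. Within the data shown here, since compound 4 also carries a substituted phenyl group, a value near that number or up at the limit seems equally open, and no step clearly beyond the scatter is expected. The expected change, if any, is downward: an at least 1.2-fold lower number from compound 3 to compound 4 (0.09 log units; that floor lies within the scatter). For compound 4 the estimate is 40 ug/mL, with an expected range of 15 ug/mL to 60 ug/mL.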

Compound 4, half-maximal cytotoxic concentration: > 50 ug/mL
Compound 4: only a limit was reported; the forecaster's own chance of this, stated with the estimate: 50%; middle value at least 1.2-fold (0.09 log units) from the limit.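

In this assay compound 4 gives > 50 ug/mL, which is a limit of the assay. Within the data shown here, this adds 2-hydroxyphenyl, the first group here with a hydrogen-bond donor on this carbon, to iodo and 3-cyanophenyl as a group whose compound has only a limit. The one readable step is an at least 1.9-fold higher number from compound 1 to compound 4 (0.28 log units; that floor lies within the scatter), while the steps to compound 4 from compound 2 and compound 3 cannot be read, and compound 1 remains the only compound with an exact number: the limit of > 50 ug/mL in this assay, at which 3 of the 4 values shown sit.

From the compounds shown here alone, how far compound 2, compound 3 and compound 4 differ from one another stays open, and the floors of their steps from compound 1 do not yet separate them from it beyond the scatter. Also open, going by these compounds, is whether a phenyl ring carrying an amine or a carboxylic acid on this carbon would give an exact number in this assay.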